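One Stereocentre Inverted in the Best Tolerated Compound

The compounds below may be only part of what the source reports. "The series", "measured", "known", "first", "only" and "open" are said of these compounds alone.

In an ADME assay on Vero cells (Chlorocebus sabaeus) for cytotoxicity, read by MTT assay, with a stated time of 72 h (a lower number here means that less compound is tolerated, a higher number that more compound is tolerated), compound 1 `COc1ccc([C@@H](O)COC(=O)/C=C/c2ccccc2)cc1OC` gives 5870 nM and compound 2 `COc1cc([C@H](O)COC(=O)/C=C/c2ccccc2)cc(OC)c1OC` gives 6440 nM, two values within the scatter of each other. Compound 3 `COc1ccccc1[C@H](O)COC(=O)/C=C/c1ccccc1` gives 14000 nM, the highest of the three numbers and beyond the scatter from both others. Compound 4 `COc1ccccc1[C@@H](O)COC(=O)/C=C/c1ccccc1`, not yet measured, differs from compound 3 only in configuration as drawn (the two compounds have the same atoms and bonds and differ only in configuration as drawn: 1 of 2 stereo elements differ; a stereocentre at a saturated chain carbon is drawn S in compound 3 and R in compound 4): a stereocentre at a saturated chain carbon is drawn S in compound 3 and R in compound 4. For the measured compounds named here, no measured pair shows a change of this kind, so the expectation is loose. The estimated step of a 1.2-fold lower number from compound 3 to compound 4 (0.07 log units; within the scatter) is expected to be slightly downward and within the scatter. Compound 4 is estimated at 12000 nM, with an expected range of 6000 nM to 24000 nM.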

Compound 4, half-maximal cytotoxic concentration: 51700 nM
Compound 4: middle estimate off by 4.3-fold (0.63 log units), on the low side; the measured number lies above the stated range.
By their numbers in this assay, from the lowest: compounds 1 and 2 (each within the scatter of the next); then compound 3; then compound 4.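

In this assay, the stereocentre at the saturated chain carbon proves to matter: going from S to R as drawn gives a 3.7-fold higher number from compound 3 to compound 4 (0.57 log units; beyond the scatter) and makes this a position where configuration alone moves the number. The earlier compounds held no such pair, and this step can be set down to that stereocentre alone for one reason: the fact that compounds 3 and 4 differ only in the configuration as drawn.

On these data alone, whether the same inversion moves the number in compound 1 or compound 2 remains open. So does whether the step would persist with an amine in place of the hydroxyl.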